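The compounds below may be only part of what the source reports. "The series", "measured", "known", "first", "only" and "open" are said of these compounds alone.

Measured compounds:
compound 1, `O=C1N/C(=N/c2csc(-c3ccc(Cl)cc3)c2)S/C1=C\c1ccccc1`: > 50000 nM
compound 2, `Cc1ccc(/C=C2\S/C(=N\c3csc(-c4ccc(Cl)cc4)c3)NC2=O)cc1`: 1500 nM
compound 3, `O=C1CS/C(=N\c2csc(-c3ccc(Cl)cc3)c2)N1c1ccccc1`: "not determined" (no result reported)

In a functional assay on SW-620 cells (Homo sapiens) for cytotoxicity, read by MTT assay, with a stated time of 72 h (on this read-out lower numbers stand for stronger inhibition and higher numbers for weaker inhibition), compound 1 gives only a limit, > 50000 nM. Compound 2 gives 1500 nM in this assay. The change between them is methyl in place of hydrogen on an aromatic carbon and it made an at least 33-fold lower number from compound 1 to compound 2 (1.52 log units; beyond the scatter); the size is a lower bound, since compound 1 sits at the limit of > 50000 nM in this assay, at which 1 of the 3 values shown sits.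

Compound 3 carries a different core; the difference between the two cores is not broken down here, and compound 3 has no result in this assay. Compound 4, `Cc1ccc(N2C(=O)CS/C2=N\c2csc(-c3ccc(Cl)cc3)c2)cc1`, is not yet measured and differs from compound 3 by methyl in place of hydrogen on an aromatic carbon, the same change as from compound 1 to compound 2. A step in the same direction is expected from compound 3 to compound 4 in this assay, resting on an at least 33-fold lower number from compound 1 to compound 2 (1.52 log units; beyond the scatter); with no value for compound 3 its size is not gauged here. Compound 4 is estimated at 6000 nM in this assay, expected between 800 nM and 50000 nM.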

Compound 4, half-maximal inhibitory concentration: > 50000 nM
Compound 4: only a limit was reported (the forecaster's own chance of this, stated with the estimate: 35%); at least 8.3-fold (0.92 log units) between middle value and limit.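

Among these compounds, compound 4 gives only a limit in this assay: the limit of > 50000 nM in this assay, at which 2 of the 4 values shown sit. With no number for compound 3, no step from compound 3 to compound 4 can be read. On these data alone, whether methyl in place of hydrogen shifts the number on this core stays open.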